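The source may hold more compounds than are shown below. What is called first, only, known or untested is meant among the compounds shown, and "the series" means these compounds.

Measured compounds:

Compound 1, `CC(C)c1c(Cc2c(Cl)cccc2Cl)nc(SCC(=O)c2ccccc2)[nH]c1=O` — in an ADME assay on MT4 cells (Homo sapiens) for cytotoxicity, read by MTT assay (on this read-out lower numbers stand for higher toxicity in this test and higher numbers for lower toxicity in this test), compound 1 gives > 56000 nM, which is a limit of the assay and not a number.
Compound 2, `CC(C)c1c(Cc2c(Cl)cccc2Cl)nc(SCC(=O)c2ccc(F)cc2)[nH]c1=O` — in this assay compound 2 gives > 54000 nM, again only a limit.
Compound 3, `CC(C)c1c(Cc2c(F)cccc2Cl)nc(SCC(=O)c2ccccc2)[nH]c1=O` — in this assay compound 3 gives > 12000 nM, also a limit.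

The change from compound 1 to compound 2 is fluoro in place of hydrogen on an aromatic carbon. Its effect in this assay is a step that the two limits leave unreadable from compound 1 to compound 2, because both compounds sit at limits, one at the limit of > 56000 nM in this assay, at which 1 of the 3 values shown sits, and the other at the limit of > 54000 nM in this assay, at which 1 of the 3 values shown sits. Nothing more can be read from that pair than that neither compound showed toxicity up to its limit.

The two cores differ as fluoro in place of chloro on an aromatic carbon. The step from compound 1 to compound 3 in this assay is a step that the two limits leave unreadable from compound 1 to compound 3, with compound 3 resting at the limit of > 12000 nM in this assay, at which 1 of the 3 values shown sits, a less demanding limit than the other two.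

Compound 4, `CC(C)c1c(Cc2c(F)cccc2Cl)nc(SCC(=O)c2ccc(F)cc2)[nH]c1=O`, is not yet measured. It differs from compound 3 by fluoro in place of hydrogen on an aromatic carbon, the same change as from compound 1 to compound 2, set on the same place of the ring. In this assay the step from compound 3 to compound 4 is expected to be a step that the limit leaves unreadable from compound 3 to compound 4, on the grounds that the same change left compound 2 at a limit just as compound 1 was. Compound 4 is therefore estimated at 40000 nM, with a likely range from 12000 nM to 150000 nM, and most probably it will again be reported only as a limit.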

Compound 4, half-maximal cytotoxic concentration: > 56000 nM
Compound 4 ended at the assay's limit (the forecaster's own chance of this, stated with the estimate: 80%); middle value at least 1.4-fold (0.14 log units) from the limit.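

In this assay compound 4 gives > 56000 nM, which is a limit of the assay and not a number. Compared with compound 3 or compound 2, it yields no step that can be read, since each of these compounds has only a limit. The compounds shown leave open the concentration at which any of them becomes toxic to the cells, and whether either fluoro change alters that concentration.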